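The compounds below may be only part of what the source reports. "The series", "measured", "known", "first", "only" and "open" are said of these compounds alone.

Compound 1 `O=c1cc(-c2ccccc2)oc2ccc(OCCCN3CCC(O)CC3)cc12`: 130 nM
Compound 2 `O=c1cc(-c2ccccc2)oc2ccc(OCCCCCCN3CCCCC3)cc12`: 101 nM

In an assay on isolated protein (Cavia porcellus) with Sigma non-opioid intracellular receptor 1 (Homo sapiens) as the target, read by radioligand binding (a higher number here means a weaker inhibitor, a lower number a stronger inhibitor), compound 2 gives 101 nM and compound 1 gives 130 nM; the step of a 1.3-fold lower number from compound 1 to compound 2 (0.11 log units; within the scatter) lies within the scatter, so neither compound is set apart. Compound 3 `O=c1cc(C2CCC2)oc2ccc(OCCCCCCN3CCCCC3)cc12` differs from compound 2 by cyclobutyl in place of phenyl on an aromatic carbon. Going by the values given here, no measured step touches this place on the shared core, so nothing in the data bears directly on the change, and the expectation rests on the structural change alone, with wide uncertainty. Compound 3 is therefore estimated at 300 nM in this assay, between 80 nM and 1200 nM. The expected step for compound 3 is a 3.0-fold higher number from compound 2 to compound 3 (0.47 log units; beyond the scatter).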

Compound 3, half-maximal inhibitory concentration: 51 nM
For compound 3 the middle estimate is 5.9-fold (0.77 log units) above the measured one, and the stated range ends above it.
By their numbers in this assay, from the lowest: compounds 3, 2 and 1 (each within the scatter of the next, the first and the last beyond it).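

Going by these compounds alone, compounds 1 and 2 both carried phenyl on this aromatic carbon next to the ring oxygen, so this is the first look at a change there. In this assay, the step of a 2.0-fold lower number from compound 2 to compound 3 (0.30 log units; within the scatter) shows that a four-membered non-aromatic ring of carbon only can stand in place of the six-membered aromatic ring without setting the two compounds apart. Nothing available explains this result. The compounds shown leave open how cyclopropyl, cyclohexyl or a pyridyl group would read at this position, and whether cyclobutyl gives a similar reading alongside a 4-hydroxypiperidin-1-yl group.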